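Solubility after swapping 4-fluorobenzyl for 1-phenylethyl

A few compounds are considered here, and "the series" means these few. Any claim that something is new, unique, unknown or untested is made for them only; others in the source may bear on it.

Compound 1 `CNC(=O)c1ccc(=O)n(Cc2cc(Br)ccc2F)c1`: >= 143 ug/mL
Compound 2 `CNC(=O)c1cc(C(=O)NC2CC2)cn(Cc2ccc(F)cc2)c1=O`: >= 162 ug/mL

Both compounds were measured in a physicochemical assay for solubility; on this read-out lower numbers stand for lower solubility and higher numbers for higher solubility. For compound 1, the reading of >= 143 ug/mL is a limit of the assay and not a number. Compound 2 stands at >= 162 ug/mL, which is likewise a limit and not a number. The two compounds therefore cannot be placed in any order, and they differ in more than one place.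

Compound 3 `CNC(=O)c1cc(C(=O)NC2CC2)cn([C@H](C)c2ccccc2)c1=O` has not yet been measured. It carries 1-phenylethyl in place of 4-fluorobenzyl on an aromatic nitrogen, and the entering group brings a defined stereocentre.

Among the measured compounds shown here, no measured pair of compounds shows a comparable change, so the expectation rests on the structural change alone. No step beyond the scatter is expected in this assay, although the reading may again be only a limit. The expected step is an at least 1.1-fold lower number from compound 2 to compound 3 (0.06 log units; that floor lies within the scatter). For compound 3 the estimated value is 140 ug/mL, with an expected range from 65 ug/mL to 195 ug/mL.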

Compound 3, solubility: >= 168 ug/mL
Compound 3 ended at the assay's limit; the forecaster's own chance of this, stated with the estimate: 55%; middle value at least 1.2-fold (0.07 log units) away from the limit.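

In this assay compound 3 gives >= 168 ug/mL, which is a limit of the assay. Compound 2 gives >= 162 ug/mL, which is also a limit. Among the compounds shown here, no step can therefore be read between compound 2 and compound 3. The compounds shown leave open whether 1-phenylethyl in place of 4-fluorobenzyl changes the reading in this assay at all, and in which direction.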